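The source may hold more compounds than are shown below. What is called first, only, known or untested is meant among the compounds shown, and "the series" means these compounds.

Compound 1 `Nc1cc(N)c2nc(-c3ccccc3)c(Oc3ccc(F)cc3)nc2c1`: 49000 nM
Compound 2 `COc1ccc(CNc2nc3cc(N)cc(N)c3nc2-c2ccccc2)cc1OC`: 34700 nM

Both numbers come from a functional assay on HOP-62 cells (Homo sapiens) for inhibition, read by sulforhodamine B assay, with a stated time of 48 h; on this read-out lower numbers stand for stronger inhibition of growth and higher numbers for weaker inhibition of growth. Compound 1 gives the higher of the two numbers, yet its nearest neighbour, compound 2, stands within the scatter, so no order between them can be claimed. Compound 3 `COc1ccc(Sc2nc3cc(N)cc(N)c3nc2-c2ccccc2)cc1` has not yet been measured. It differs from compound 1 in one place: (4-methoxyphenyl)sulfanyl in place of 4-fluorophenoxy on an aromatic carbon. Among the measured compounds shown here, no step between measured compounds is known here, so this change has no precedent in the data. Compound 3 is expected to stay close to compound 1, with the expected step of a 1.2-fold lower number from compound 1 to compound 3 (0.09 log units; within the scatter) in this assay lying within the scatter. Compound 3 is estimated at 40000 nM, between 15000 nM and 100000 nM.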

Compound 3, concentration for total growth inhibition: < 100000 nM
Compound 3 ended at the assay's limit (the forecaster's own chance of this, stated with the estimate: 20%); the middle value does not contradict the limit.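

Among the compounds shown here, compound 3 ended at < 100000 nM, a limit of the assay and not a number, so no step from compound 1 to compound 3 can be read. The compounds shown leave open whether (4-methoxyphenyl)sulfanyl in place of 4-fluorophenoxy changes growth inhibition at all.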